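The source may hold more compounds than are shown below. What is called first, only, known or untested is meant among the compounds shown, and "the series" means these compounds.

Working notes on the series.

For the measured compounds named here, compound 2 `COc1cc(NC(=O)Nc2cc(Nc3ccc(C)c(F)c3)ncn2)cc(OC)c1` gives 38% in a functional assay on NCI-H1581 cells (Homo sapiens) for inhibition, read by MTT assay, with a stated time of 48 h, tested at 10 uM (a lower number here means less inhibition, a higher number more inhibition at the concentration tested (going by the name of the read-out)), and stands lowest of the three numbers measured so far. Compound 3 `COc1cc(Br)ccc1Nc1cc(NC(=O)Nc2c(Cl)cccc2Cl)ncn1` is nearest, at 47.3%, a gap that lies within the scatter; compound 1 `COc1ccc(F)cc1Nc1cc(NC(=O)Nc2c(Cl)cccc2Cl)ncn1` is furthest, at 73.1%, a gap beyond the scatter.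

Compound 4 `COc1cc(NC(=O)Nc2cc(Nc3cc(Br)ccc3OC)ncn2)cc(OC)c1` is not yet measured. It differs from compound 2 in one place: 5-bromo-2-methoxyphenyl in place of 3-fluoro-4-methylphenyl on a nitrogen on an aromatic ring.

Going by the values given here, the only measured step on the same nitrogen is a number 25.8 percentage points lower from compound 1 to compound 3 (beyond the scatter), but it swaps one methoxy-bearing aryl for another on a different urea partner, so it does not bear directly on the present change. Between compound 2 and compound 3, which carry different aryls on that nitrogen and different urea partners, the two values show no difference beyond the scatter. Among the compounds with values here, no measured step therefore points to a change beyond the scatter in this assay, and the expected step of a number 4 percentage points higher from compound 2 to compound 4 (within the scatter) is small.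

Compound 4 is estimated at 42%, within 25% to 60%.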

Compound 4, a percentage reported as inhibition, at one concentration (the size of the read-out at that concentration, not a potency): 23.1%
Compound 4: middle estimate off by 18.9 percentage points, on the high side, outside the stated range (below it).
By their numbers in this assay, from the lowest: compound 4; then compounds 2 and 3 (each within the scatter of the next); then compound 1.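

In this assay, 5-bromo-2-methoxyphenyl in place of 3-fluoro-4-methylphenyl on a nitrogen on an aromatic ring gives a number 14.9 percentage points lower from compound 2 to compound 4 (beyond the scatter), so this position also responds to a change of aryl group with the urea partner shared by this pair. Alongside a number 25.8 percentage points lower from compound 1 to compound 3 (beyond the scatter), which belongs to the other urea partner, both steps read at this position run downward, although each exchanges a different pair of groups and two steps establish no general pattern. No measurement here bears on why the number falls with this change.

Which part of 5-bromo-2-methoxyphenyl goes with the step, the methoxy or the bromine, remains open. Also open, on these data alone, is how this position would read with an aryl group carrying an amine or a carboxylic acid.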